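Working notes: from compound 3 to compound 4

A few compounds are considered here, and "the series" means these few. Any claim that something is new, unique, unknown or untested is made for them only; others in the source may bear on it.

- Compound 1 `S=c1[nH]nc(C2=C(Cl)c3ccccc3CCC2)o1` gives 3430 nM
- Compound 2 `ClC1=C(c2nnc(-c3ccccc3)o2)CCCc2ccccc21` gives 675 nM
- Compound 3 `Cc1ccc(-c2nnc(C3=C(Cl)c4ccccc4CCC3)o2)cc1` gives 6810 nM

In a functional assay on PANC-1 cells (Homo sapiens) for antiproliferative activity, read by sulforhodamine B assay, with a stated time of 48 h (on this read-out lower numbers stand for stronger inhibition of growth and higher numbers for weaker inhibition of growth), compound 3 at 6810 nM and compound 1 at 3430 nM lie within the scatter of each other. Compound 2 at 675 nM is separated from compound 3 by a gap that exceeds the scatter, with compound 3 on the higher side.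

The next compound is compound 4 `O=[N+]([O-])c1ccc(-c2nnc(C3=C(Cl)c4ccccc4CCC3)o2)cc1` which differs from compound 3 in one place. The counted difference is nitro in place of methyl on an aromatic carbon and no other part of the structure changes.

For the measured compounds named here, only one measured step bears on this place: a 10-fold higher number from compound 2 to compound 3 (1.00 log units; beyond the scatter) for methyl in place of hydrogen on an aromatic carbon. That step shows that the number can move well beyond the scatter with a small change here. Going by the values given here, no nitro compound has been measured, so both the direction and the size remain weakly supported. With compound 2 at 675 nM as the only lower reference among the aryl compounds, a partial return towards it is expected in this assay rather than a further rise.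

The expected change is a 2.7-fold lower number from compound 3 to compound 4 (0.44 log units; beyond the scatter) as a rough estimate. For compound 4 the estimated value is 2500 nM with an expected range from 500 nM to 10000 nM as its limits.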

Compound 4, concentration for 50% growth inhibition: 3980 nM
The estimate for compound 4 lay 1.6-fold (0.20 log units) below the measured number; measured number inside the range.
By their numbers in this assay, from the lowest: compound 2; then compounds 1, 4 and 3 (each within the scatter of the next).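

In this assay the new step is a 1.7-fold lower number from compound 3 to compound 4 (0.23 log units; within the scatter) and so does not separate nitro from methyl at this place on the six-membered aromatic ring, even though the entering nitro has 3 heavy atoms and 2 hydrogen-bond acceptors and the leaving methyl has 1 heavy atom and 0 acceptors. Against the unsubstituted compound, the result is a 5.9-fold higher number from compound 2 to compound 4 (0.77 log units; beyond the scatter) and this gives a second group, alongside methyl, that stands beyond the scatter on the higher side of hydrogen, so the rise no longer rests on methyl alone, although the pattern covers only these two groups and no compound shown goes against it. No measurement is available that bears on the reason for this pattern.

Still open, going by these compounds, is whether any group at this place can give a lower number than hydrogen does in compound 2, or whether every replacement of that hydrogen stays on the higher side. An amine, a fluorine atom or a carboxylic acid at the same place would show whether the rise extends beyond methyl and nitro.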